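This account rests on a few compounds, and the source may have more. Where it says the series, first, only, none or still open, it means among the compounds named here.

Three compounds share one core and differ only in the amine that sits on a saturated chain carbon, three bonds along the chain from an oxygen on an aromatic ring. Compound 1, `CCN(CC)CCCOc1cc2ncnc(Nc3ccc(C#N)cc3)c2cc1OC`, carries a diethylamino group there, and in a functional assay on DU-145 cells (Homo sapiens) for antiproliferative activity, read by MTT assay, with a stated time of 72 h (a lower number here means a stronger inhibitor, a higher number a weaker inhibitor), compound 1 gives 68900 nM. Compound 2, `COc1cc2c(Nc3ccc(C#N)cc3)ncnc2cc1OCCCN(C)Cc1ccccc1`, carries a benzyl(methyl)amino group instead. In this assay compound 2 reaches only a limit, > 100000 nM, not a number. Compound 3, `COc1cc2c(Nc3ccc(C#N)cc3)ncnc2cc1OCCCN1CCCCC1`, carries a piperidin-1-yl group, and in this assay compound 3 gives 24400 nM, the lowest of the two numbers. The other value shown is a limit: the limit of > 100000 nM in this assay, at which 1 of the 3 values shown sits. The measured steps are small: an at least 1.4-fold higher number from compound 1 to compound 2 (0.16 log units; that floor lies within the scatter), a 2.8-fold lower number from compound 1 to compound 3 (0.45 log units; beyond the scatter) and an at least 4.0-fold lower number from compound 2 to compound 3 (0.61 log units; beyond the scatter).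

Compound 4, `CCOC(=O)C1CCN(CCCOc2cc3ncnc(Nc4ccc(C#N)cc4)c3cc2OC)CC1`, keeps the piperidine of compound 3 and adds a group to it: ethoxycarbonyl in place of hydrogen on a saturated ring carbon. Among the compounds with values here, no measured step tests a substituent on that ring; the steps that exist swap the whole amine and move the number only modestly, as in a 2.8-fold lower number from compound 1 to compound 3 (0.45 log units; beyond the scatter). The expectation for compound 4 is therefore a step from compound 3 that stays close to the scatter, a 1.2-fold higher number from compound 3 to compound 4 (0.09 log units; within the scatter). Compound 4 is estimated at 30000 nM, within a range from 12000 nM to 80000 nM.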

Compound 4, half-maximal inhibitory concentration: 52300 nM
For compound 4 the middle estimate is 1.7-fold (0.24 log units) below the measured one; the range from low to high includes it.
By their numbers in this assay, from the lowest: compound 3; then compounds 4 and 1 (each within the scatter of the next). At a limit, above all of these: compound 2.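

Until now every step swapped the whole amine, whereas this one keeps the piperidine and adds a group to it, three ring bonds from the ring nitrogen, and in this assay that gives a 2.1-fold higher number from compound 3 to compound 4 (0.33 log units; beyond the scatter), so a substituent on this saturated ring carbon does register, though only modestly. The addition also leaves the gain of the bare piperidine behind, since the step from the diethylamino compound, a 1.3-fold lower number from compound 1 to compound 4 (0.12 log units; within the scatter), lies within the scatter and the two amines cannot be told apart in this assay. Compound 2 remains at a limit and not at a number, so its step gives only a floor, an at least 1.9-fold lower number from compound 2 to compound 4 (0.28 log units; that floor lies within the scatter), and the true size of that gap is unknown: the limit of > 100000 nM in this assay, at which 1 of the 4 values shown sits.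

The compounds shown do not tell whether this rise belongs to the ethoxycarbonyl group in particular or would follow from any group on that ring carbon, and a carboxylic acid or a methyl group in the same place would separate the two. They also do not show whether the same addition would read the same way on a longer chain.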